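Two Limits and an Acetyl Oxime Ester to Come

The source may hold more compounds than are shown below. What is called first, only, known or untested is meant among the compounds shown, and "the series" means these compounds.

compound 1 `CCOC(=O)CCO/N=C(/c1ccc(OC)c(OC)c1OC)c1cccc2ccccc12`: > 20000 nM
compound 2 `COc1cc(COC(c2ccc(OC)c(OC)c2OC)c2cccc3ccccc23)cc(OC)c1`: > 20000 nM

In a functional assay on THP-1 cells (Homo sapiens) for inhibition, read by sulforhodamine B assay, with a stated time of 48 h (a higher number here means a weaker inhibitor, a lower number a stronger inhibitor), compound 1 gives > 20000 nM, which is a limit of the assay and not a number. Compound 2 gives > 20000 nM in this assay, again only a limit. Both values sit at the same limit (the limit of > 20000 nM in this assay, at which 2 of the 2 values shown sit), so compound 1 cannot be ranked against compound 2.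

Compound 3 `COc1ccc(/C(=N/OC(C)=O)c2cccc3ccccc23)c(OC)c1OC` is not yet measured. It differs from compound 1 by acetyl in place of 2-(ethoxycarbonyl)ethyl on an oxygen, in words acetyl in place of 2-(ethoxycarbonyl)ethyl on an oxygen. Within the data shown here, no measured step exists here; the expected step is a step that the limit leaves unreadable from compound 1 to compound 3, nothing beyond the scatter. Compound 3 is expected to give about 30000 nM, between 8000 nM and 100000 nM, most likely again reported only as a limit.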

Compound 3, half-maximal inhibitory concentration: > 20000 nM
Compound 3: only a limit was reported (the forecaster's own chance of this, stated with the estimate: 80%); the middle value does not contradict the limit.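

Compound 3 is again only a limit, so no step can be read between compound 1 and compound 3: the limit of > 20000 nM in this assay, at which 3 of the 3 values shown sit.

The compounds shown leave open how strongly any of them acts in this assay and whether acetyl in place of 2-(ethoxycarbonyl)ethyl changes anything.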